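Swapping furan-3-yl for thiophen-3-yl on the shared core

This account rests on a few compounds, and the source may have more. Where it says the series, first, only, none or still open, it means among the compounds named here.

Compound 3 `CCN(CC)C(=O)C1=C(C)NC(=O)NC1c1ccoc1` gives 12% in an assay on membranes from HEK293 cells for displacement of a labelled ligand from adenosine receptor A2b (Homo sapiens), read by scintillation counting, with a stated time of 30 min, tested at 1 uM; a higher number here means more inhibition at the concentration tested (going by the name of the read-out), a lower number less inhibition. Among the three compounds with numbers, compound 3 holds the second highest figure. Nearest to it is compound 1 `CC1=C(C(=O)C2CC2)C(c2ccoc2)NC(=O)N1`, which in this assay gives 10%, a gap within the scatter; furthest is compound 2 `CC(=O)C1=C(C)NC(=O)NC1c1ccsc1`, which in this assay gives 24%, a gap beyond the scatter.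

The step to compound 4 `CCN(CC)C(=O)C1=C(C)NC(=O)NC1c1ccsc1` is thiophen-3-yl in place of furan-3-yl on a saturated ring carbon.

Among the compounds with values here, only one measured step connects two compounds that differ in a single place, a number 2 percentage points higher from compound 1 to compound 3 (within the scatter), and it concerns the carbonyl substituent, not the aromatic ring, so it says nothing direct about the change at hand. Compound 2 carries thiophen-3-yl and compound 3 carries furan-3-yl, but the two also differ in the group on the carbonyl carbon, so their values can only hint that the thiophen-3-yl compound sits higher. On that hint a small rise is expected, though the support is thin. Compound 4 is therefore estimated at 18% in this assay, with a range from 6% to 32%, which means an expected step of a number 6 percentage points higher from compound 3 to compound 4 (within the scatter).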

Compound 4, a percentage reported as inhibition, at one concentration (the size of the read-out at that concentration, not a potency): 11%
Compound 4: the middle estimate sits 7 percentage points above what was measured; low and high end bracket the measured number.
By their numbers in this assay, from the lowest: compounds 1, 4 and 3 (each within the scatter of the next); then compound 2.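

In this assay, within the data shown here, the first direct comparison at this saturated ring carbon gives a number 1 percentage points lower from compound 3 to compound 4 (within the scatter), so with diethylamino on the carbonyl carbon, thiophen-3-yl and furan-3-yl cannot be told apart in this assay. The hint of a thiophen-3-yl advantage, which rested on a pair differing in two places, therefore finds no support in this matched pair. Among these compounds, with thiophen-3-yl held constant, the change on the carbonyl carbon does register, with a modest a number 13 percentage points lower from compound 2 to compound 4 (beyond the scatter), which places the only step beyond the scatter at the carbonyl substituent rather than at the ring position; no evidence is available to explain either result.

The compounds shown leave open whether the exchange of furan-3-yl for thiophen-3-yl would also make no difference with methyl on the carbonyl carbon, where compound 2 gives 24%. They also leave open how this ring position would respond to a group other than these two, such as a phenyl ring or a pyridine ring, and how the carbonyl position would respond to a smaller amine such as dimethylamino.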